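The compounds below may be only part of what the source reports. "The series", "measured", "known", "first", "only" and "open" are said of these compounds alone.

Compound 1 `COCOc1cc(/C=C/C(=O)OCC(=O)Nc2ccc(OC)cc2)ccc1OCc1ccccc1` gives in a functional assay on HL-60 cells (Homo sapiens) for cytotoxicity, read by MTT assay, with a stated time of 72 h (on this read-out higher numbers stand for weaker inhibition and lower numbers for stronger inhibition), only a limit, > 200000 nM.
Compound 2 `COCOc1cc(/C=C/C(=O)OCC(=O)Nc2ccc(Cl)cc2)ccc1OCc1ccccc1` gives in this assay likewise only a limit, > 200000 nM.
Compound 3 `O=C(COC(=O)/C=C/c1ccc(O)c(O)c1)Nc1ccc(Cl)cc1` gives in this assay 8100 nM.

The change from compound 2 to compound 1 is methoxy in place of chloro on an aromatic carbon. Its step, a step that the two limits leave unreadable from compound 2 to compound 1, cannot be sized because the limit of > 200000 nM in this assay, at which 2 of the 3 values shown sit, covers both ends. How the core of compound 3 differs from that of compound 2 is not broken down here. Compound 4 `COc1ccc(NC(=O)COC(=O)/C=C/c2ccc(O)c(O)c2)cc1` carries the same change on the core of compound 3: methoxy in place of chloro on an aromatic carbon, at a place described in the same words. The measured step offers no guide, so the expectation for compound 4 rests on compound 3 alone, whose value 8100 nM is the only number shown; the step is estimated as a 1.9-fold higher number from compound 3 to compound 4 (0.27 log units; within the scatter). Compound 4 is therefore expected to give about 15000 nM, most likely between 4000 nM and 60000 nM.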

Compound 4, half-maximal inhibitory concentration: 72100 nM
The estimate for compound 4 lay 4.8-fold (0.68 log units) below the measured number, outside the stated range (above it).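

In this assay, the change from 4-chlorophenyl to 4-methoxyphenyl on the core of compound 3 gives an 8.9-fold higher number from compound 3 to compound 4 (0.95 log units; beyond the scatter), so on this core the methoxy compound needs a clearly higher concentration for the same inhibition. The same change on the other core gives no readable step, because both compounds there give only a limit: the limit of > 200000 nM in this assay, at which 2 of the 4 values shown sit. So the result describes one core only, and it does not show whether the change would have a similar size or even the same direction on another core.

The compounds shown leave open how other groups at this place on the core of compound 3 would behave, such as an amine or a carboxylic acid. With a single readable step, they also leave open whether any trend holds across the series.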